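Cytotoxicity notes on a thiophene-substituted bicyclic amine series

The compounds below may be only part of what the source reports. "The series", "measured", "known", "first", "only" and "open" are said of these compounds alone.

Measured compounds:
- compound 1, `CSc1ccc(CN[C@@H]2C[C@H]3C[C@@H]([C@H]2C)C3(C)C)s1`: 25000 nM
- compound 2, `Cc1ccc(CN[C@@H]2C[C@H]3C[C@@H]([C@H]2C)C3(C)C)s1`: 780 nM

For the measured compounds named here, in an ADME assay on MDCK cells (Canis lupus familiaris) for cytotoxicity, read by microscopy, with a stated time of 48 h (on this read-out higher numbers stand for lower toxicity in this test and lower numbers for higher toxicity in this test), compound 2 gives 780 nM, the lowest of the two numbers so far; the nearest is compound 1, which gives 25000 nM. Going by the values given here, the one measured step, a 32-fold lower number from compound 1 to compound 2 (1.51 log units; beyond the scatter), concerns methyl in place of methylsulfanyl on an aromatic carbon and is large.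

Compound 3, `CCc1ccc(CN[C@@H]2C[C@H]3C[C@@H]([C@H]2C)C3(C)C)s1`, is not yet measured. It differs from compound 2 by methyl in place of hydrogen on a saturated chain carbon bound to an aromatic carbon; seen one bond further out, methyl becomes ethyl. Among the compounds with values here, no measured step touches this position, so the step from compound 1 to compound 2 bears on it only as a sign that substitution on the aromatic ring can move this read-out strongly. For growth of a chain by one carbon the expected step is small: compound 3 is estimated close to compound 2, with a 1.3-fold higher number from compound 2 to compound 3 (0.11 log units; within the scatter) inside the scatter. The estimate for compound 3 is 1000 nM, range 300 nM to 4000 nM.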

Compound 3, minimum cytotoxic concentration: 1560 nM
The estimate for compound 3 lay 1.6-fold (0.19 log units) below the measured number, within the range that was stated.
By their numbers in this assay, from the lowest: compounds 2 and 3 (each within the scatter of the next); then compound 1.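

In this assay, growing methyl to ethyl gives a 2.0-fold higher number from compound 2 to compound 3 (0.30 log units; within the scatter) and so does not separate the two compounds on this read-out. Ethyl in place of methylsulfanyl gives a 16-fold lower number from compound 1 to compound 3 (1.20 log units; beyond the scatter) and is large, so the large gap to compound 1 is now seen with two different chains, methyl and ethyl, rather than with methyl alone. No measurement at hand gives a reason for either step.

As far as these compounds go, whether a longer chain such as propyl or a branched one such as isopropyl would stay close to compound 2 and compound 3 remains open. Also open, from the compounds shown here alone, is whether the gap to compound 1 belongs to the sulfur atom itself, which a group such as ethylsulfanyl or methoxy could help to test.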